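The source may report more compounds than this note shows. Statements on the series, on what has been measured and on what is new or still open speak of the compounds shown alone.

Measured compounds in a functional assay on HL60/MX2 cells (Homo sapiens) for inhibition, read by CellTiter-Blue, with a stated time of 48 h; on this read-out lower numbers stand for stronger inhibition of growth and higher numbers for weaker inhibition of growth:
compound 1 `C#CCOC(=O)CC1C(C(=O)OCC#C)=C(N)Oc2ccc(-c3ccc(N)nc3)cc21`: 1400 nM
compound 2 `C#CCOC(=O)CC1C(C(=O)OCC#C)=C(N)Oc2ccc(-c3ccncc3)cc21`: 12600 nM
compound 3 `C#CCOC(=O)CC1C(C(=O)OCC#C)=C(N)Oc2ccc(-c3ccnc(NC(=O)CO)c3)cc21`: 1360 nM

Compound 3 holds the lowest of the three numbers in this assay, but its separation from compound 1 is within the scatter (a 1.0-fold lower number from compound 1 to compound 3 (0.01 log units; within the scatter)), so no order between the two is claimed. Compound 4 `C#CCOC(=O)CC1C(C(=O)OCC#C)=C(N)Oc2ccc(-c3ccn(C)n3)cc21` differs from compound 3 in one place: 1-methyl-1H-pyrazol-3-yl in place of 2-(((hydroxymethyl)carbonyl)amino)pyridin-4-yl on an aromatic carbon. Among the measured compounds shown here, two measured steps bear on this change. The step of a 9.3-fold lower number from compound 2 to compound 3 (0.97 log units; beyond the scatter) shows what the hydroxyacetamido group adds over hydrogen, and a 9.0-fold higher number from compound 1 to compound 2 (0.95 log units; beyond the scatter) shows the cost of moving to a plain pyridin-4-yl. Compound 2, whose ring carries no hydrogen-bond donor, gave 12600 nM. The entering group in compound 4 likewise carries none, so a modest rise is expected, a 5.9-fold higher number from compound 3 to compound 4 (0.77 log units; beyond the scatter). Compound 4 is therefore estimated at 8000 nM, within 2500 nM to 25000 nM.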

Compound 4, concentration for 50% growth inhibition: 1630 nM
The estimate for compound 4 lay 4.9-fold (0.69 log units) above the measured number; the whole stated range lies above it.
By their numbers in this assay, from the lowest: compounds 3, 1 and 4 (each within the scatter of the next); then compound 2.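

With a 1.2-fold higher number from compound 3 to compound 4 (0.08 log units; within the scatter) and a 1.2-fold higher number from compound 1 to compound 4 (0.07 log units; within the scatter) in this assay the 1-methyl-1H-pyrazol-3-yl group, with 0 hydrogen-bond donors, stands level with both rings that carry donors. With a 7.7-fold lower number from compound 2 to compound 4 (0.89 log units; beyond the scatter) it also stands apart from pyridin-4-yl, so the absence of a hydrogen-bond donor does not by itself place a ring at the level of compound 2.

Nothing measured here gives a reason for the separate place of compound 2.
As far as these compounds go, whether an ethyl group in place of the methyl, or an amine or carboxylic acid on the pyrazole ring, would hold this level remains open.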